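The source may hold more compounds than are shown below. What is called first, only, known or untested is meant among the compounds shown, and "the series" means these compounds.

Compound 1 `Cc1ccc(/C=C2\Cc3ccccc3C2=O)cc1`: 59100 nM
Compound 2 `O=C1CCCCC/C1=C\c1ccccc1`: 261000 nM
Compound 3 `O=C1CCCCC/C1=C\c1ccc(F)cc1`: 291000 nM

In a functional assay on L1210 cells (Mus musculus) for inhibition (on this read-out lower numbers stand for stronger inhibition and higher numbers for weaker inhibition), compound 2 gives 261000 nM. Together with compound 3 it forms the high end of the three numbers, the two lying within the scatter of each other, while compound 1 lies clearly lower at 59100 nM.

Compound 4 `O=C1CCCCC/C1=C\c1cccc(Cl)c1` differs from compound 2 by one change: chloro in place of hydrogen on an aromatic carbon. In words, this is chloro in place of hydrogen on an aromatic carbon.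

For the measured compounds named here, only one measured step bears on this change, the fluoro in place of hydrogen on an aromatic carbon, which gave a 1.1-fold higher number from compound 2 to compound 3 (0.05 log units; within the scatter). Going by the values given here, no measured compound carries chloro, so this evidence is indirect. On the strength of a 1.1-fold higher number from compound 2 to compound 3 (0.05 log units; within the scatter), no step beyond the scatter is expected in this assay, and no direction is firmly indicated.

The estimated step is a 1.1-fold lower number from compound 2 to compound 4 (0.05 log units; within the scatter). For compound 4 the expected value is 230000 nM, with an estimated range from 120000 nM to 400000 nM.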

Compound 4, half-maximal inhibitory concentration: 144000 nM
The estimate for compound 4 lay 1.6-fold (0.20 log units) above the measured number; the measured number falls inside the stated range.
By their numbers in this assay, from the lowest: compound 1; then compounds 4, 2 and 3 (each within the scatter of the next, the first and the last beyond it).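

Compound 4 is the only compound shown with chloro, and the only one with a group at this place on the ring, meta to a group of 9 heavy atoms. In this assay this change gives a 1.8-fold lower number from compound 2 to compound 4 (0.26 log units; within the scatter), so chloro here can't be told apart from hydrogen, just as fluoro could not in the step with a 1.1-fold higher number from compound 2 to compound 3 (0.05 log units; within the scatter). Neither halogen step on the core of compound 2 therefore moves the number beyond the scatter, and nothing measured here offers an explanation for the size of the chloro step.

As far as these compounds go, whether an amine or a carboxylic acid at this same place would give a step beyond the scatter remains open. From the compounds shown here alone, it is also open whether chloro at this place would act in the same way on the core of compound 1.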